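A Longer Chain on a Weak Antiproliferative Compound

The source may hold more compounds than are shown below. What is called first, only, known or untested is meant among the compounds shown, and "the series" means these compounds.

In a functional assay on SW480 cells (Homo sapiens) for antiproliferative activity, read by MTT assay, with a stated time of 48 h (a lower number here means a stronger inhibitor, a higher number a weaker inhibitor), compound 1 `CCCCCCCC(CCO)n1cnc2c(N(C)C)ncnc21` gives > 50000 nM, which is a limit and not a number. Within the data shown here, compound 2 `CCCCCCCCC(CCO)n1cnc2c(N(C)C)ncnc21` gives 21600 nM and compound 3 `CCCCCCCCC(CCO)n1cnc2c(N)ncnc21` gives 20700 nM as the only two true numbers so far. Placing amino where dimethylamino stood gives a 1.0-fold lower number from compound 2 to compound 3 (0.02 log units; within the scatter), so these two stand level and this step says nothing about the chain.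

Compound 4 `CCCCCCCCCC(CCO)n1cnc2c(N(C)C)ncnc21` keeps the dimethylamino group and carries one change to the chain of compound 2 (methyl in place of hydrogen on a saturated chain carbon, nine bonds along the chain from an aromatic nitrogen). The closest guide is the same kind of addition made eight bonds along the chain, which gave an at least 2.3-fold lower number from compound 1 to compound 2 (0.36 log units; beyond the scatter). Among the measured compounds shown here, that step starts from a limit, so its true size remains open, and it is the only chain step available. A further modest drop is therefore expected, though no change at all would not surprise. The expected step is a 1.7-fold lower number from compound 2 to compound 4 (0.22 log units; within the scatter) in this assay. The estimate for compound 4 is 13000 nM, with an expected range from 5000 nM to 32000 nM.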

Compound 4, half-maximal inhibitory concentration: 12200 nM
For compound 4 the middle estimate is 1.1-fold (0.03 log units) above the measured one; the range from low to high includes it.
By their numbers in this assay, from the lowest: compounds 4, 3 and 2 (each within the scatter of the next). At a limit, above all of these: compound 1.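

Methyl in place of hydrogen, nine bonds along the chain, gives a 1.8-fold lower number from compound 2 to compound 4 (0.25 log units; within the scatter) in this assay, so this single addition cannot be told apart from no change at all. Read across the whole stretch, ethyl in place of hydrogen on the saturated chain carbon eight bonds along gives an at least 4.0-fold lower number from compound 1 to compound 4 (0.61 log units; beyond the scatter), which shows a difference beyond the scatter that now spans the longest chain shown. The true size of that step stays open because compound 1 is held at a limit, not a number: the limit of > 50000 nM in this assay, at which 1 of the 4 values shown sits.

From the compounds shown here alone, whether a longer chain would bring any further change remains open, as does the effect of an amine or a carboxylic acid on the chain. Also open, going by these compounds, is whether amino would stand level with dimethylamino on the chain of compound 4, as it does on the chain of compound 2.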